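The compounds below may be only part of what the source reports. "The series", "measured", "known", "first", "only" and "open" are said of these compounds alone.

Measured so far:
compound 1 `Cc1ccccc1C(=O)NC(CCN(C)C)c1ccc(Cl)cc1` — 175%
compound 2 `Cc1cccc(C(=O)NC(CCN(C)C)c2ccc(Cl)cc2)c1C` — 159%

In an assay on NIH3T3 cells with Urotensin-2 receptor (Homo sapiens) as the target (a higher number here means a larger maximal response, a lower number a smaller maximal response), compound 2 holds the lowest of the two numbers; its nearest neighbour is compound 1, whose value in this assay stands higher, and the step of a number 16 percentage points lower from compound 1 to compound 2 (beyond the scatter) lies beyond the scatter. That step is the only measured one, and it concerns a methyl in place of hydrogen on an aromatic carbon.

Compound 3 `Cc1ccc(C)c(C(=O)NC(CCN(C)C)c2ccc(Cl)cc2)c1` differs from compound 2 by 2,5-dimethylphenyl in place of 2,3-dimethylphenyl on a carbonyl carbon. Within the data shown here, the two structures hold the same atoms, joined differently, so the one measured step bears on it only loosely: it tells how the series answered to an added methyl, not to a methyl moved to another aromatic carbon. With both methyls kept and the rest of the molecule unchanged, no step beyond the scatter is expected in this assay in either direction.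

Compound 3 is therefore expected to give 160% in this assay, within a range from 140% to 180%. The step this estimate means, a number 1 percentage points higher from compound 2 to compound 3 (within the scatter), is expected to stay within the scatter.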

Compound 3, largest response reached (reported as efficacy), in percent of the reference or control that the assay uses: 164%
Compound 3: the middle estimate sits 4 percentage points below what was measured, within the range that was stated.
By their numbers in this assay, from the lowest: compounds 2 and 3 (each within the scatter of the next); then compound 1.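

In this assay, 2,5-dimethylphenyl in place of 2,3-dimethylphenyl on the carbonyl carbon gives a number 5 percentage points higher from compound 2 to compound 3 (within the scatter) and so separates the two placements of the methyl groups in this pair by no more than the usual variation between repeats. Methyl in place of hydrogen on an aromatic carbon gives a number 11 percentage points lower from compound 1 to compound 3 (beyond the scatter) and thus repeats the direction of a number 16 percentage points lower from compound 1 to compound 2 (beyond the scatter) with a second dimethylphenyl isomer, so both dimethylphenyl compounds shown stand under compound 1, and none of the three compounds goes against this. The data at hand offer no explanation for either the shared drop or the match between the two isomers.

Still open, going by these compounds, is whether this drop belongs to methyl itself or would also follow from another group at the same places, such as chlorine, methoxy or trifluoromethyl. Also open, on these data alone, is how far the maximal response depends on the dimethylamino end, which stays the same in all three compounds and could be tested with a pyrrolidine or a longer chain to the amine.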